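Swapping a methyl for a methoxy on a long-lived compound

The source may hold more compounds than are shown below. What is called first, only, known or untested is meant among the compounds shown, and "the series" means these compounds.

Values so far in an ADME assay (a lower number here means that the compound disappears faster, a higher number that the compound lasts longer), are these
Compound 1 `COc1ccc(C[S+]([O-])c2ncccc2C(=O)Nc2ccncc2)c(OC)c1C` gives 11.6 h
Compound 2 `COc1cc(OC)c(OC)cc1C[S+]([O-])c1ncccc1C(=O)Nc1ccncc1` gives 0.14 h

Compound 1 at 11.6 h stands higher of the two, and compound 2 lies far under it, well beyond the scatter. The next compound is compound 3 `COc1ccc(C[S+]([O-])c2ncccc2C(=O)Nc2ccncc2)c(OC)c1OC` which differs from compound 1 in one place (methoxy in place of methyl on an aromatic carbon) with methoxy in place of methyl on an aromatic carbon, ortho to two methoxy groups. For the measured compounds named here, no measured pair shows this exchange alone. Like compound 3, compound 2 carries methoxy groups and no methyl on its aromatic ring, and compound 2 gives 0.14 h in this assay though its methoxy groups sit differently. A fall beyond the scatter is therefore expected, smaller than the gap between the measured pair, with an estimated step of a 3.9-fold lower number from compound 1 to compound 3 (0.59 log units; beyond the scatter) in this assay as the expected size. For compound 3 the expected value is 3 h within an estimated range of 0.5 h to 12 h.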

Compound 3, half-life: 116 h
Beside the measured number, compound 3's estimate is 39-fold (1.59 log units) below it, and the stated range ends below it.
By their numbers in this assay, from the lowest: compound 2; then compound 1; then compound 3.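

In this assay, putting methoxy in place of methyl on this aromatic carbon, ortho to two methoxy groups, gives a 10-fold higher number from compound 1 to compound 3 (1.00 log units; beyond the scatter). For the compounds shown here, this is the first direct reading of the exchange at this position: with the rest of the molecule held constant, the methoxy compound lasts longer, so a methoxy group here does not by itself bring a short half-life. Nothing available explains the rise.

Going by these compounds, how other groups would behave on this carbon remains open, whether a hydrogen, a fluorine, an ethoxy or an amine. Also open is whether the same exchange would give a similar step with the two neighbouring methoxy groups replaced, and the compounds shown cannot say which feature gives compound 2 its short half-life.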